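A Hydroxymethyl Replaced by an Anilide on the Shared Core

The compounds below may be only part of what the source reports. "The series", "measured", "known", "first", "only" and "open" are said of these compounds alone.

Of the compounds shown here, three on a shared core have been measured in a functional assay on blood (Homo sapiens), with a stated time of 60 min, in the presence of a further agent that is not named here; a lower number here means that less compound is needed, a higher number that more compound is needed for the effect. Compound 1 `O=C(OCc1ccccc1)C1(S(=O)(=O)c2ccc(Oc3ccc(OC(F)(F)F)cc3)cc2)CCC2(CCNCC2)C1` carries a benzyloxycarbonyl group; in this assay compound 1 gives > 15000 nM, which is a limit of the assay and not a number. Compound 2 `O=S(=O)(c1ccc(Oc2ccc(OC(F)(F)F)cc2)cc1)C1(CO)CCC2(CCNCC2)C1` carries a hydroxymethyl group instead; in this assay compound 2 gives > 15000 nM, again a limit. Compound 3 `CN(C)S(=O)(=O)NC(=O)C1(S(=O)(=O)c2ccc(Oc3ccc(OC(F)(F)F)cc3)cc2)CCC2(CCNCC2)C1` carries a (dimethylsulfamoyl)carbamoyl group; in this assay compound 3 gives > 15000 nM, also a limit. Because of the limit of > 15000 nM in this assay, at which 3 of the 3 values shown sit, the steps a step that the two limits leave unreadable from compound 1 to compound 2, a step that the two limits leave unreadable from compound 1 to compound 3 and a step that the two limits leave unreadable from compound 2 to compound 3 cannot be read in size or direction.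

Compound 4 `Nc1ccc(F)cc1NC(=O)C1(S(=O)(=O)c2ccc(Oc3ccc(OC(F)(F)F)cc3)cc2)CCC2(CCNCC2)C1` is not yet measured. It differs from compound 2 as follows: (2-amino-5-fluorophenyl)carbamoyl in place of hydroxymethyl on a saturated ring carbon. Within the data shown here, no measured step bears on this change, since every measured value is a limit. The new group is larger than hydroxymethyl and unlike the groups in compound 1 and compound 3, so the measured limits give no guide to its effect.

Compound 4 is therefore estimated at 10000 nM in this assay, with a range from 1500 nM to 30000 nM. This corresponds to an expected step of an at least 1.5-fold lower number from compound 2 to compound 4 (0.17 log units; that floor lies within the scatter), with a real chance that only a limit is reported.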

Compound 4, half-maximal effective concentration: > 15000 nM
Compound 4: only a limit was reported; the forecaster's own chance of this, stated with the estimate: 50%; middle value at least 1.5-fold (0.17 log units) from the limit.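

In this assay compound 4 gives > 15000 nM, which is a limit of the assay and not a number. Its steps to compound 1, compound 2 and compound 3 cannot be read in size or direction, because every value stops at the same limit: the limit of > 15000 nM in this assay, at which 4 of the 4 values shown sit.

The compounds shown leave open which group on this saturated ring carbon, if any, would give a readable value on the shared core.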